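The source may hold more compounds than are shown below. What is called first, only, known or untested is meant among the compounds shown, and "the series" means these compounds.

Two compounds of the series have numbers in an assay on blood for inhibition of C-X-C chemokine receptor type 3 (Homo sapiens), with a stated time of 30 min (on this read-out lower numbers stand for stronger inhibition and higher numbers for weaker inhibition), so far. Compound 1 `C[C@@H]1CN(c2sc(Br)nc2-c2nc3ccccc3[nH]2)CCN1C(=O)Cn1cnc2cccnc21` gives 526 nM. Compound 2 `Cc1nc(C)n(CC(=O)N2CCN(c3sc(C(F)(F)F)nc3-c3cnc(OC(C)C)nc3)C[C@H]2C)n1` gives 216 nM, the lower of the two, and its gap to compound 1 lies beyond the scatter. For the measured compounds named here, no pair of measured compounds differs in only one place, so no single step has been measured. Compound 3 `Cc1nc(C)n(CC(=O)N2CCN(c3sc(C(F)(F)F)nc3-c3cnc(C4CC4)nc3)C[C@H]2C)n1` differs from compound 2 by cyclopropyl in place of isopropoxy on an aromatic carbon. With nothing comparable measured, the expected step from compound 2 to compound 3 is a 1.2-fold higher number from compound 2 to compound 3 (0.06 log units; within the scatter), none beyond the scatter in either direction. Compound 3 is estimated at 250 nM, within 100 nM to 650 nM.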

Compound 3, half-maximal inhibitory concentration: 674 nM
Compound 3: middle estimate off by 2.7-fold (0.43 log units), on the low side; measured number above the stated range.
By their numbers in this assay, from the lowest: compound 2; then compounds 1 and 3 (each within the scatter of the next).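

On the aromatic carbon between two ring nitrogen atoms, the group matters in this assay: cyclopropyl in place of isopropoxy reads as a 3.1-fold higher number from compound 2 to compound 3 (0.49 log units; beyond the scatter) on this single pair. For the compounds shown here, this is the first single change read, and it shows that this place is not indifferent to the swap. No measurement at hand bears on the reason for the step.

As far as these compounds go, whether methoxy or dimethylamino at this place would stay nearer to compound 2 or to compound 3 remains open. Also open, from the compounds shown here alone, is whether the same step would hold on the core of compound 1.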